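Replacing a side group with chloro on the shared core

The compounds below may be only part of what the source reports. "The series", "measured", "known", "first", "only" and "open" are said of these compounds alone.

In a functional assay on K562 cells (Homo sapiens) for antiproliferative activity, read by MTT assay, with a stated time of 48 h (a lower number here means a stronger inhibitor of growth, a higher number a weaker inhibitor of growth), the measured compounds give these values
- Compound 1 `COc1ccc(N(C)c2ncnc3c2ncn3Cc2ccc(OC)c(OC)c2)cc1` gives > 100000 nM as a limit
- Compound 2 `COc1ccc(N(C)c2ncnc3c2ncn3Cc2cc(OC)cc(OC)c2)cc1` gives 42000 nM as a number
- Compound 3 `COc1ccc(N(C)c2ncnc3c2ncn3Cc2cc(OC)c(OC)c(OC)c2)cc1` gives > 100000 nM as a limit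

Compound 3 stands only at a limit, not at a number. Compound 4 `COc1cc(Cn2cnc3c(Cl)ncnc32)cc(OC)c1OC` carries chloro in place of (4-methoxyphenyl)(methyl)amino on an aromatic carbon, with chloro in place of (4-methoxyphenyl)(methyl)amino on an aromatic carbon as the full count. Neither an at least 2.3-fold lower number from compound 1 to compound 2 (0.37 log units; beyond the scatter) nor an at least 2.3-fold higher number from compound 2 to compound 3 (0.37 log units; beyond the scatter) touches this place, so both are only a loose guide. Within the data shown here, compound 2 at 42000 nM is the one real number, so a reading in that region is expected. The estimated move is an at least 1.6-fold lower number from compound 3 to compound 4 (0.22 log units; that floor lies within the scatter) in this assay and its size is uncertain. The expected value for compound 4 is 60000 nM within an estimated range from 15000 nM to 150000 nM overall.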

Compound 4, concentration for 50% growth inhibition: > 50000 nM
Compound 4: a limit, no number; the forecaster's own chance of this, stated with the estimate: 45%; the middle value does not contradict the limit.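

Compound 3 and compound 4 both stand only at limits, not at numbers, and the step between them cannot be read. The compounds shown leave open whether chloro or (4-methoxyphenyl)(methyl)amino gives stronger growth inhibition at this place.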